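Replacing Amino with Phenyl on a Shared Core

The source may report more compounds than this note shows. Statements on the series, on what has been measured and on what is new or still open speak of the compounds shown alone.

Of the compounds shown here, three built on one shared core have been tested in a functional assay on U-251 cells (Homo sapiens) for inhibition, read by sulforhodamine B assay, with a stated time of 48 h; on this read-out lower numbers stand for stronger inhibition of growth and higher numbers for weaker inhibition of growth. Compound 1, `O=CN1CCN(c2ccc(Cl)cc2)C1=S`, gives 14400 nM in this assay. Compound 2, `N#C/C(=C\N1CCN(C(=O)c2ccco2)C1=S)C(N)=O`, gives 11500 nM. Compound 3, `COc1cc(C(=O)N2CCN(C=O)C2=S)cc(OC)c1OC`, gives 16400 nM. Compound 2 therefore carries the lowest of the three numbers, but its gaps to compound 1 and to compound 3 both lie within the usual scatter of repeated measurements, so the three compounds cannot be placed in any order against each other.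

Compound 4, `N#C/C(=C\N1CCN(C(=O)c2ccco2)C1=S)C(=O)c1ccccc1`, has not yet been measured. It differs from compound 2 in one place: phenyl in place of amino on a carbonyl carbon. Cut one bond further out, the same difference reads carbamoyl to benzoyl.

Among the compounds with values here, no pair of measured compounds shows this change, so the measured values give no direct guide to its size. The three measured numbers sit close together although the groups attached to the shared core differ widely, which points to a modest outcome here as well. The step from compound 2 to compound 4 is expected to be a 1.4-fold lower number from compound 2 to compound 4 (0.16 log units; within the scatter), toward a somewhat lower number, with a result inside the scatter being entirely possible. Compound 4 is estimated at 8000 nM, with a plausible range from 2500 nM to 25000 nM.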

Compound 4, concentration for 50% growth inhibition: 17000 nM
Estimate against measurement, compound 4: 2.1-fold (0.33 log units) below; measured number inside the range.
By their numbers in this assay, from the lowest: compounds 2, 1, 3 and 4 (each within the scatter of the next).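

In this assay, phenyl in place of amino on a carbonyl carbon gives a 1.5-fold higher number from compound 2 to compound 4 (0.17 log units; within the scatter), so this change, which also reads as carbamoyl to benzoyl, separates compound 2 and compound 4 by no more than repeated measurements would. Within the data shown here, this is the first direct reading at this position, and it shows that a swap from 1 heavy atom to 6 heavy atoms, which adds a six-membered aromatic ring and removes the hydrogen-bond donor of amino, leaves no readable difference in this growth read-out. Nothing measured here bears on what lies behind this result.

Only amino and phenyl are shown on this carbonyl carbon, so it remains open whether a dimethylamino group, a methoxy group or a longer alkyl chain in the same place would give a step beyond the scatter. On these data alone, it is also open whether a phenyl ring carrying a further group, such as a chlorine atom or a methoxy group, would move the number away from that of compound 4.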